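This account rests on a few compounds, and the source may have more. Where it says the series, first, only, none or still open, it means among the compounds named here.

Working notes on the series. Three compounds have numbers in a functional assay (trachea) for antagonist activity, with Cavia porcellus as the target; a higher number here means a more potent compound, by a factor of ten per unit of this negative logarithm, a lower number a less potent compound. Compound 1, `COc1cc(-c2nn[nH]n2)ccc1Cn1ncc2ccc(NC(=O)OC3CCCC3)cc21`, gives 7.7 in this assay. Compound 2, `COc1cc(C(=O)NS(=O)(=O)c2cccs2)ccc1Cn1ccc2ccc(NC(=O)CC3CCCC3)cc21`, gives 9.6 in this assay. Compound 3, `CCCCC(CC)C(=O)Nc1ccc2ccn(Cc3ccc(C(=O)NS(=O)(=O)c4ccccc4)cc3)c2c1`, gives 6.8 in this assay. Compound 2 thus stands highest of the three, beyond the scatter from both others: compound 1 sits nearest, compound 3 furthest below it. No pair among these three differs in one place only, so the numbers give no isolated step to lean on.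

The next compound, compound 4, `COc1cc(C(=O)NS(=O)(=O)c2ccc3ccccc3c2)ccc1Cn1ccc2ccc(NC(=O)CC3CCCC3)cc21`, is to be measured in this assay. It differs from compound 2 in one place: naphthalen-2-yl in place of thiophen-2-yl on a sulfonyl sulfur. The acyl sulfonamide itself is kept, only the aryl group on the sulfonyl sulfur changes.

Nothing measured here bears directly on such an exchange, since compound 3 carries a different amide and lacks the methoxy as well as having its own sulfonyl aryl group. The expectation is that the step from compound 2 to compound 4 stays small, a number 0.30 log units lower from compound 2 to compound 4 (within the scatter), if anything slightly downward, but not beyond the scatter. For compound 4 the estimate in this assay is 9.3, with a likely range from 8.5 to 10.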

Compound 4, negative logarithm of the antagonist equilibrium constant: 8.3
Compound 4: the middle estimate sits 1.00 log units above what was measured; the measured number lies below the stated range.
By their numbers in this assay, from the lowest: compound 3; then compound 1; then compound 4; then compound 2.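

The sulfonyl aryl group is not a free position in this series: with the acyl sulfonamide and the rest of compound 2 kept, exchanging thiophen-2-yl for naphthalen-2-yl on a sulfonyl sulfur gives a number 1.30 log units lower from compound 2 to compound 4 (beyond the scatter) in this assay. For the compounds shown here, this is the first isolated step, and it shows that the read-out responds strongly to the aryl group at this place, although compound 4 still gives 8.3. The exchange changes several things at once, replacing a five-membered aromatic ring with one hetero atom by two six-membered aromatic rings of carbon only, and no measurement at hand separates these changes or gives a reason for the step.

A single step cannot show whether the number falls steadily as the aryl group grows or whether thiophen-2-yl is a particular optimum, so a pyridine ring or a plain methyl on the sulfonyl sulfur would be informative. As far as these compounds go, it also remains open whether the same exchange gives a step of similar size when the cyclopentyl-bearing amide of compound 2 is replaced by a longer chain.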